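From a hexyl chain to a cyanobenzyl group

The compounds below may be only part of what the source reports. "The series", "measured", "known", "first", "only" and "open" are said of these compounds alone.

Compound 1 `O=C1OC(Cc2nc(Cc3ccccc3)no2)c2ccccc21`: > 10000 nM
Compound 2 `CCCCCCOc1ccc(C(O)C2OC(=O)c3c(OC)cc(OC)cc32)cc1`: 5360 nM

Of the compounds shown here, two have so far been tested in a functional assay on RAW264.7 cells (Mus musculus) for inhibition, read by Griess assay, with stated times of 1 h and 24 h; a lower number here means a stronger inhibitor, a higher number a weaker inhibitor. For compound 1 the value > 10000 nM is a limit of the assay, not a measured number. Among the compounds with values here, compound 2 gives 5360 nM, the only real number. The other entry is the limit of > 10000 nM in this assay, at which 1 of the 2 values shown sits, so compound 2 has no measured neighbour against which its place can be judged.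

Compound 3 `COc1cc(OC)c2c(c1)C(C(O)c1ccc(OCc3ccc(C#N)cc3)cc1)OC2=O` has not yet been measured. It differs from compound 2 in one place: 4-cyanophenyl in place of pentyl on a saturated chain carbon bound to an oxygen on an aromatic ring. Within the data shown here, no step between two measured compounds is available, so the size of this change cannot be read from a precedent. The expected step from compound 2 to compound 3 in this assay is a 1.3-fold lower number from compound 2 to compound 3 (0.13 log units; within the scatter), which is no larger than the usual scatter. Compound 3 is therefore estimated at 4000 nM, with a range from 1200 nM to 15000 nM.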

Compound 3, half-maximal inhibitory concentration: 7360 nM
For compound 3 the middle estimate is 1.8-fold (0.26 log units) below the measured one; low and high end bracket the measured number.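

Exchanging hexyloxy for (4-cyanobenzyl)oxy gives, in this assay, a 1.4-fold higher number from compound 2 to compound 3 (0.14 log units; within the scatter). Within the data shown here, this is the first step that joins two measured numbers, and it gives the position its first reading: a saturated chain and a group holding a six-membered aromatic ring and a nitrile cannot be told apart here, even though the two differ in size and shape. Nothing measured here gives a reason for this outcome.

A plain benzyl group would show whether the nitrile plays any part in the reading of compound 3, since the ring and the nitrile enter together in this change. As far as these compounds go, it also remains open whether a group of another kind on this oxygen, such as a chain ending in an amine or a carboxylic acid, would move the number beyond the scatter.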